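Amide-substituent variation in the chalcone series: compound 3

The compounds below may be only part of what the source reports. "The series", "measured", "known", "first", "only" and "open" are said of these compounds alone.

The series shares a core seen in compound 1 `COc1cc(/C=C/C(=O)c2cccc(NC(=O)c3c(Cl)cccc3Cl)c2)ccc1O` and compound 2 `COc1cc(/C=C/C(=O)c2cccc(NC(=O)c3ccccc3)c2)ccc1O`, which differ only in the group on the carbonyl carbon of the amide. In a functional assay on Vero cells (Chlorocebus sabaeus) for inhibition (a higher number here means a weaker inhibitor, a lower number a stronger inhibitor), compound 1 gives 2.48 ug/mL, and compound 2 gives 3.47 ug/mL. The step of a 1.4-fold higher number from compound 1 to compound 2 (0.15 log units; within the scatter) is the only one measured so far. Of the two numbers, compound 1 holds the lower one, but its separation from compound 2 lies within the scatter, so no order between them is claimed.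

Compound 3 `CCOC(=O)C(=O)Nc1cccc(C(=O)/C=C/c2ccc(O)c(OC)c2)c1` alters compound 1 at the same place: ethoxycarbonyl in place of 2,6-dichlorophenyl on a carbonyl carbon. Among the compounds with values here, the single measured step bears on this only loosely: it exchanged one ring for another and stayed within the scatter, whereas here a ring leaves and no ring enters. Within the data shown here, no measured pair shows what an ethoxycarbonyl group does at this carbonyl carbon. The two compounds seen suggest tolerance at this position, with no pattern claimed beyond them. Compound 3 is expected to give 4 ug/mL, within 1.5 ug/mL to 12 ug/mL. The estimated step of a 1.6-fold higher number from compound 1 to compound 3 (0.21 log units; within the scatter) leans toward a higher number, with uncertainty wider than the scatter.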

Compound 3, half-maximal inhibitory concentration: > 50 ug/mL
Compound 3: a limit, no number; the forecaster's own chance of this, stated with the estimate: 10%; middle value at least 12-fold (1.09 log units) away from the limit.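

In this assay compound 3 gives > 50 ug/mL, which is a limit of the assay and not a number. The position on the carbonyl carbon of the amide is sensitive to the group it carries, which the exchange of one ring for another did not reveal: replacing 2,6-dichlorophenyl with ethoxycarbonyl reads as an at least 20-fold higher number from compound 1 to compound 3 (1.30 log units; beyond the scatter), and replacing phenyl with ethoxycarbonyl reads as an at least 14-fold higher number from compound 2 to compound 3 (1.15 log units; beyond the scatter). The tolerance suggested by compound 1 and compound 2 therefore does not extend to ethoxycarbonyl, and the true size of both steps stays undefined, since they rest on a limit: the limit of > 50 ug/mL in this assay, at which 1 of the 3 values shown sits.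

The compounds shown cannot separate the loss of the aromatic ring from the entry of ethoxycarbonyl, as the change does both at once, and they give no view of whether any group without a ring can be accepted at this carbonyl carbon. Going by these compounds, how a cyclohexyl ring, a propyl chain, a carboxylic acid or an amine would read at this place remains open.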